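Propanoyl on the Sulfonamide Nitrogen: A Second Test

The compounds below may be only part of what the source reports. "The series", "measured", "known", "first", "only" and "open" are said of these compounds alone.

Of the compounds shown here, three sharing a pyrazole-based scaffold have been tested in a functional assay on the whole organism (strain Wistar) with Rattus norvegicus as the target, read by paw edema; on this read-out higher numbers stand for an effect only at larger amounts of compound and lower numbers for an effect already at smaller amounts. Compound 1 `CCC(=O)OCc1cc(-n2nc(C(F)(F)F)cc2-c2ccc(Br)cc2)ccc1S(N)(=O)=O` carries a free sulfonamide; in this assay compound 1 gives 17 mg/kg. Compound 2 `CCC(=O)NS(=O)(=O)c1ccc(-n2nc(C(F)(F)F)cc2-c2ccc(Br)cc2)cc1COC(=O)CC` differs from compound 1 in a single place: propanoyl in place of hydrogen on a sulfonamide nitrogen. In this assay compound 2 gives 12.5 mg/kg. This change brought a 1.4-fold lower number from compound 1 to compound 2 (0.13 log units; within the scatter), so the two results cannot be told apart with confidence. Compound 3 `NS(=O)(=O)c1ccc(-n2nc(C(F)(F)F)cc2-c2ccc3c(c2)CCO3)cc1CO` rests on a different core; the difference between the two cores is not broken down here. In this assay compound 3 gives 22.3 mg/kg, and its result lies within the scatter of both compound 1 and compound 2, so no order among the three can be claimed.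

Compound 4 `CCC(=O)NS(=O)(=O)c1ccc(-n2nc(C(F)(F)F)cc2-c2ccc3c(c2)CCO3)cc1CO` has not been measured. It differs from compound 3 in exactly one place: propanoyl in place of hydrogen on a sulfonamide nitrogen. For the measured compounds named here, this is the same change as the one from compound 1 to compound 2, made on the same kind of place, a sulfonamide nitrogen whose other neighbour is the sulfonyl sulfur.

Because the earlier step of this change was a 1.4-fold lower number from compound 1 to compound 2 (0.13 log units; within the scatter), a step of similar size is expected for compound 4, and the estimate is a 1.4-fold lower number from compound 3 to compound 4 (0.14 log units; within the scatter). Starting from compound 3 at 22.3 mg/kg, compound 4 is expected to give about 16 mg/kg in this assay, with a likely range from 9 mg/kg to 30 mg/kg; the single earlier example is a thin basis, so the range is kept wide.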

Compound 4, dose for half-maximal effect: 7.5 mg/kg
Estimate against measurement, compound 4: 2.1-fold (0.33 log units) above; measured number outside the range, below it.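

In this assay, adding propanoyl to the sulfonamide nitrogen on the core of compound 3 gives a 3.0-fold lower number from compound 3 to compound 4 (0.47 log units; beyond the scatter), a step that can be read as real, although modest. Set beside the earlier step on the core of compound 1, this step cannot be told apart from it: the same change on two cores in this assay, a 1.4-fold lower number (0.13 log units; within the scatter) from compound 1 to compound 2 and a 3.0-fold lower number (0.47 log units; beyond the scatter) from compound 3 to compound 4, 2.2-fold (0.34 log units) apart, within the scatter of two such steps. So the result fits the idea that the change carries from one core to the other, with a lower number on both, but it does not establish a fixed size for the step, since there are only two pairs and only the second lies clear of the scatter on its own.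

The compounds shown leave open whether a different group on the same nitrogen, such as the shorter acetyl, the longer butanoyl or a benzoyl group, would give a step like these. They also leave open whether propanoyl would act in the same way on a third core, which would be a firmer test than two pairs can offer.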